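A few compounds are considered here, and "the series" means these few. Any claim that something is new, unique, unknown or untested is made for them only; others in the source may bear on it.

In a functional assay on M21 cells (Homo sapiens) for antiproliferative activity, read by sulforhodamine B assay, with a stated time of 48 h (on this read-out higher numbers stand for weaker inhibition and lower numbers for stronger inhibition), compound 1 (`Cc1ccc(OS(=O)(=O)c2ccc(N3CCN(C)C3=O)cc2)c(C)c1`) gives 1800 nM and compound 2 (`COc1cccc(OS(=O)(=O)c2ccc(N3CCN(C)C3=O)cc2)c1`) gives 1600 nM. Within the data shown here, the one measured step, a 1.1-fold lower number from compound 1 to compound 2 (0.05 log units; within the scatter), leaves compound 2 level with compound 1 within the scatter, and no order can be drawn between them. Compound 3 (`CCN1CCN(c2ccc(S(=O)(=O)Oc3cccc(OC)c3)cc2)C1=O`) keeps the 3-methoxyphenyl group of compound 2 and differs at one other place: methyl in place of hydrogen on a saturated chain carbon bound to an amide-type nitrogen in a ring. This turns methyl into ethyl, giving 3-ethyl-2-oxoimidazolidin-1-yl in place of 3-methyl-2-oxoimidazolidin-1-yl. The measured step bears on this only loosely. Among the measured compounds shown here, it exchanges the group on an oxygen and leaves the methyl untouched, and no measured pair tests the present change. For the measured compounds named here, it shows only that one structural change in this small set left the number within the scatter. With no measurement at this place, no step beyond the scatter is expected in this assay, and neither direction is favoured. The expected step is a 1.1-fold lower number from compound 2 to compound 3 (0.03 log units; within the scatter). The estimate for compound 3 is 1500 nM, with an expected range of 600 nM to 3800 nM.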

Compound 3, half-maximal inhibitory concentration: 7000 nM
The estimate for compound 3 lay 4.7-fold (0.67 log units) below the measured number; measured number above the stated range.
By their numbers in this assay, from the lowest: compounds 2 and 1 (each within the scatter of the next); then compound 3.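

In this assay, replacing 3-methyl-2-oxoimidazolidin-1-yl with 3-ethyl-2-oxoimidazolidin-1-yl gives a 4.4-fold higher number from compound 2 to compound 3 (0.64 log units; beyond the scatter), so this place in the structure responds to the addition of a methyl on a saturated chain carbon bound to an amide-type nitrogen in a ring. Among these compounds, the earlier exchange of groups on an oxygen, a 1.1-fold lower number from compound 1 to compound 2 (0.05 log units; within the scatter), stayed within the scatter and gave no sign of such a response, which makes this the first step in the set beyond the scatter, and it runs toward weaker inhibition. The compounds shown come with no measurement that accounts for this loss.

The compounds shown leave open whether the trend continues with a longer chain such as propyl, or what a hydrogen in place of the methyl, or a hydroxyethyl group or an amine at the end of the chain, would do. They also leave open whether the ethyl group would have the same effect with the 2,4-dimethylphenyl group of compound 1, since the step is read only with the 3-methoxyphenyl group.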